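Drawing One Stereocentre: From Compound 2 to Compound 4

The source may report more compounds than this note shows. Statements on the series, on what has been measured and on what is new or still open speak of the compounds shown alone.

Measured compounds:
compound 1, `C[C@@H](C#Cc1cccc(C(=O)NCc2ccccc2C(F)(F)F)c1)N(O)C(N)=O`: 700 nM
compound 2, `C[C@H](C#Cc1cccc(C(=O)NCCC(c2ccc(F)cc2)c2ccc(C(F)(F)F)cc2)c1)N(O)C(N)=O`: 220 nM
compound 3, `C[C@H](C#Cc1cccc(C(=O)NCCC(c2ccc(F)cc2)c2ccc(OC(F)(F)F)cc2)c1)N(O)C(N)=O`: 260 nM

These values come from an assay for inhibition of Polyunsaturated fatty acid 5-lipoxygenase (Homo sapiens), read by HPLC, with stated times of 15 min and 10 min; a higher number here means a weaker inhibitor, a lower number a stronger inhibitor. Compound 2 holds the lowest of the three numbers. Its nearest neighbour is compound 3, which lies a 1.2-fold higher number from compound 2 to compound 3 (0.07 log units; within the scatter), a change of trifluoromethoxy for trifluoromethyl on an aromatic carbon that leaves the two within the scatter of each other. Compound 1, with its shorter amide substituent, sits furthest away, and that gap lies beyond the scatter.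

Compound 4, `C[C@H](C#Cc1cccc(C(=O)NCC[C@@H](c2ccc(F)cc2)c2ccc(C(F)(F)F)cc2)c1)N(O)C(N)=O`, keeps every atom and bond of compound 2. The difference is this: the two compounds have the same atoms and bonds; at least one stereo element is drawn with a configuration in one of them and without one in the other: 1 of 2 stereo elements differ; a stereocentre at a saturated chain carbon is drawn without a configuration in compound 2 and R in compound 4. In plain terms, compound 2 is drawn as a mixture at that chain carbon, while compound 4 is drawn as one of its two forms.

Among the compounds with values here, no measured step here concerns a stereocentre; the one step on record swaps a group and is within the scatter, so it says nothing about how the two forms of compound 2 split the activity. If the drawn form carries most of the activity of the mixture, the number could fall somewhat; if it carries little, the number would rise. The estimate therefore sits near the value of compound 2 with a wide range, and compound 4 is expected to give 180 nM, between 70 nM and 700 nM, a step of a 1.2-fold lower number from compound 2 to compound 4 (0.09 log units; within the scatter).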

Compound 4, half-maximal inhibitory concentration: 160 nM
Estimate against measurement, compound 4: 1.1-fold (0.05 log units) above, and the stated range covers the measured number.
By their numbers in this assay, from the lowest: compounds 4, 2 and 3 (each within the scatter of the next); then compound 1.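

In this assay, within the data shown here, fixing the chain carbon as R comes with a 1.4-fold lower number from compound 2 to compound 4 (0.14 log units; within the scatter), and this is the first step here that touches a stereocentre rather than swapping a group. The single form stands level with compound 2, which is drawn as a mixture, so the R form at this carbon holds on to the activity seen for that mixture, and the number of the mixture does not come from the other form alone. The reading of this step rests on one structural fact: the fact that one of compounds 2 and 4 is drawn with a defined configuration and the other without, at the place where they differ.

On these data alone, the S form at this carbon stays open, so how far the two forms differ from each other cannot be told from these compounds. Also open, as far as these compounds go, is whether the R form would hold its activity when another group, such as a nitrile or a carboxylic acid, takes the place of trifluoromethyl on the aromatic carbon.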